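The source may hold more compounds than are shown below. What is called first, only, known or untested is meant among the compounds shown, and "the series" means these compounds.

Measured so far:
- compound 1, `CCN(Cc1c[nH]nn1)C(=O)COc1ccc(C)cc1`: 31100 nM
- compound 2, `CCC(C)N(Cc1cccs1)C(=O)COc1ccc(C)cc1`: 2000 nM

Of the compounds shown here, two have been measured in an assay on HEK293 cells for agonist activity at transient receptor potential cation channel subfamily M member 8 (Homo sapiens), read by fluorescence and calcium flux, with a stated time of 15 min; a lower number here means that less compound is needed, a higher number that more compound is needed for the effect. Compound 1 stands at the highest of the two numbers; the nearest is compound 2, whose number is lower by a margin beyond the scatter. Compound 1 and compound 2 differ in more than one place, so no single step between measured compounds is shown.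

Compound 3, `CCN(Cc1ccccc1)C(=O)COc1ccc(C)cc1`, is not yet measured. It differs from compound 1 in one place: phenyl in place of 1H-1,2,3-triazol-4-yl on a saturated chain carbon bound to an amide-type nitrogen. Among the compounds with values here, compound 2 carries a different five-membered ring at the same position and a different chain on the amide-type nitrogen, so it does not isolate this change; it shows only that a lower number than that of compound 1 is reachable.

For compound 3 a step in this assay toward a lower number is expected, of moderate size, a 5.2-fold lower number from compound 1 to compound 3 (0.71 log units; beyond the scatter). Compound 3 is estimated at 6000 nM, within a range of 1500 nM to 20000 nM.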

Compound 3, half-maximal effective concentration: 1880 nM
The estimate for compound 3 lay 3.2-fold (0.50 log units) above the measured number, within the range that was stated.
By their numbers in this assay, from the lowest: compounds 3 and 2 (each within the scatter of the next); then compound 1.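

In this assay, phenyl in place of 1H-1,2,3-triazol-4-yl on a saturated chain carbon bound to an amide-type nitrogen gives a 17-fold lower number from compound 1 to compound 3 (1.22 log units; beyond the scatter). This shows, with the rest of the structure held constant, that the ring at this position alone can shift the number by a large step, which compound 2 could not isolate. The step changes ring size, hetero atoms, and hydrogen-bond donors and acceptors together, and no measurement bears on which of these accounts for it.

The compounds shown leave open how far each of these differences contributes. A pyridinyl or cyclohexyl ring at this place, or a chlorine or methoxy group on the phenyl, remains to be placed against compound 3.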